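What the step to compound 3 may bring

The compounds below may be only part of what the source reports. "The series", "measured", "known", "first", "only" and "open" are said of these compounds alone.

Measured so far in a physicochemical assay for solubility, with a stated time of 24 h, at pH 2.2 (a higher number here means a more soluble compound, a lower number a less soluble compound), for two compounds:
- Compound 1 `O=C(NC[C@@H]1[C@H]2CN(C(=O)OCc3cc(Cl)cc(Cl)c3)C[C@@H]12)c1ccc2[nH]c(=O)oc2c1` gives < 1 ug/mL as a limit of the assay
- Compound 2 `CC(OC(=O)N1C[C@@H]2[C@@H](CNC(=O)c3ccc4[nH]c(=O)oc4c3)[C@@H]2C1)c1cc(Cl)cc(Cl)c1` gives < 1 ug/mL as a limit of the assay

Compound 2 offers no number to start from. In this assay compound 2 stands at < 1 ug/mL as a limit and not a number. The data so far hold only the limit of < 1 ug/mL in this assay, at which 2 of the 2 values shown sit, and no readable value. Compound 3 `Cc1cc(COC(=O)N2C[C@@H]3[C@@H](CNC(=O)c4ccc5[nH]c(=O)oc5c4)[C@@H]3C2)no1` carries one change from compound 2, namely a group of 7 heavy atoms (5 carbon, 1 nitrogen, 1 oxygen; one five-membered aromatic ring with 2 hetero atoms) in place of a group of 10 heavy atoms (8 carbon, 2 chlorine; one six-membered aromatic ring of carbon only), on an oxygen next to a carbonyl group on an oxygen next to a carbonyl group. Within the data shown here, the sole measured step is a step that the two limits leave unreadable from compound 1 to compound 2 and it concerns a different change, so it gives no size to carry over. An upward step is expected from the structural change alone, though its size is poorly constrained. The expected change is an at least 10-fold higher number from compound 2 to compound 3 (1.00 log units; beyond the scatter) as estimated here. For compound 3 the estimated value is 10 ug/mL with an expected range from 2 ug/mL to 50 ug/mL in this assay once measured.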

Compound 3, solubility: > 86 ug/mL
Compound 3 gave a limit, no number; the forecaster's own chance of this, stated with the estimate: 20%; at least 8.6-fold (0.93 log units) between middle value and limit.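

Among these compounds, compound 1 and compound 2 showed only a limit in this assay, so the group on an oxygen next to a carbonyl group is the first change here with a readable effect: an at least 86-fold higher number from compound 2 to compound 3 (1.93 log units; beyond the scatter). The comparison with the 3,5-dichlorophenyl group of compound 1 points the same way, with 5-methyl-1,2-oxazol-3-yl in its place: an at least 86-fold higher number from compound 1 to compound 3 (1.93 log units; beyond the scatter). Both steps are minimum sizes with a limit at each end, yet they show that this one position can shift the read-out strongly in this series.

From the compounds shown here alone, the true value of compound 3 remains unknown, and this change alters the ring and the group size together, so the two cannot be separated. Going by these compounds, whether a plain phenyl or a short chain carrying an amine at this place would give a number between the two limits also stays open.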